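Methyl on the fused ring of compound 1

The source may hold more compounds than are shown below. What is called first, only, known or untested is meant among the compounds shown, and "the series" means these compounds.

Three compounds of this series have numbers in a functional assay on MCF7 cells (Homo sapiens) for inhibition; a lower number here means a stronger inhibitor, a higher number a weaker inhibitor. Compound 1 `CCn1c(=O)/c(=C2\Sc3ccccc3N2C)s/c1=C\c1ccncc1Nc1ccccc1C` gives 990 nM. Compound 2 `CCn1c(=O)/c(=C2\Sc3ccccc3N2C)s/c1=C\c1ccncc1Nc1ccccc1Cl` gives 750 nM, and compound 3 `CCn1c(=O)/c(=C2\Sc3cc(F)ccc3N2C)s/c1=C\c1ccncc1Nc1ccccc1C` gives 1300 nM. Compound 1 thus sits between the other two on the numbers shown, but both of its steps are small: a 1.3-fold lower number from compound 1 to compound 2 (0.12 log units; within the scatter), and a 1.3-fold higher number from compound 1 to compound 3 (0.12 log units; within the scatter).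

Compound 4 `CCn1c(=O)/c(=C2\Sc3ccc(C)cc3N2C)s/c1=C\c1ccncc1Nc1ccccc1C` differs from compound 1 in one place: methyl in place of hydrogen on an aromatic carbon. Within the data shown here, the step that bears most directly on it is the one from compound 1 to compound 3, where a substituent also enters the same fused ring system and the number hardly moves. The step from compound 1 to compound 2 concerns a substituent on the other aromatic ring and is also within the scatter. No change to either ring has moved this assay beyond the scatter so far.

The expected step is therefore a 1.0-fold higher number from compound 1 to compound 4 (0.00 log units; within the scatter), no real shift. Compound 4 is estimated at 1000 nM in this assay, within a range from 500 nM to 2100 nM.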

Compound 4, half-maximal inhibitory concentration: 400 nM
The estimate for compound 4 lay 2.5-fold (0.40 log units) above the measured number; measured number below the stated range.
By their numbers in this assay, from the lowest: compounds 4, 2, 1 and 3 (each within the scatter of the next, the first and the last beyond it).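

Among these compounds, in the assay this assay, the step of a 2.5-fold lower number from compound 1 to compound 4 (0.39 log units; beyond the scatter) for methyl in place of hydrogen is the first to lie beyond the scatter, though it is modest and rests on a single pair. The step of a 1.3-fold higher number from compound 1 to compound 3 (0.12 log units; within the scatter) for fluoro in place of hydrogen on the same fused system stays within the scatter, so substitution on this system does not always leave the number unchanged. No measured evidence accounts for the methyl step.

As far as these compounds go, whether this step belongs to methyl itself or to its place on the ring stays open, with no ethyl, methoxy or amine at this carbon and no methyl at the carbon carrying fluoro in compound 3. Also open, from the compounds shown here alone, is whether methyl here combines with the chloro group of compound 2 on the other aromatic ring.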